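A few compounds are considered here, and "the series" means these few. Any claim that something is new, unique, unknown or untested is made for them only; others in the source may bear on it.

Of the compounds shown here, three built on one shared core have been measured in a functional assay on OVCAR-5 cells (Homo sapiens) for inhibition, read by sulforhodamine B assay, with a stated time of 48 h; a higher number here means a weaker inhibitor of growth, a lower number a stronger inhibitor of growth. Compound 1 `O=C(Nc1cccc(-n2cc(-c3ccncc3)c(-c3ccc(Cl)c(O)c3)n2)c1)Nc1cccc(C(F)(F)F)c1` gives 13700 nM. Compound 2 `COc1cc(-c2nn(-c3cccc(NC(=O)Nc4cc(C(F)(F)F)cc(C(F)(F)F)c4)c3)cc2-c2ccncc2)ccc1Cl` gives 937 nM. Compound 3 `COc1cc(-c2nn(-c3cccc(NC(=O)c4cccc(C(F)(F)F)c4)c3)cc2-c2ccncc2)ccc1Cl` gives 4010 nM, the second highest of the three numbers: its nearest neighbour is compound 1, whose number is higher by a gap beyond the usual scatter of this assay, and its furthest is compound 2, whose number is lower by a gap that also lies beyond the scatter.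

Compound 4 `COc1cc(-c2nn(-c3cccc(NC(=O)Nc4ccc(Cl)c(Cl)c4)c3)cc2-c2ccncc2)ccc1Cl` has not yet been measured in this assay. It differs from compound 3 in a single place: (3,4-dichlorophenyl)amino in place of 3-(trifluoromethyl)phenyl on a carbonyl carbon. Read one bond further out, the change is from (3-(trifluoromethyl)phenyl)carbonyl to (3,4-dichlorophenyl)carbamoyl, so compound 4 carries a carbamoyl where compound 3 carries a carbonyl.

Among the compounds with values here, no pair of measured compounds shows exactly this step, so its size must be guessed from the three numbers. Compound 2 also carries a carbamoyl and gives 937 nM, a number well below that of compound 3. On that basis a downward step in this assay, beyond the scatter, is expected from compound 3 to compound 4, of about a 2.7-fold lower number from compound 3 to compound 4 (0.43 log units; beyond the scatter). For compound 4 the estimated value is 1500 nM, with a range from 500 nM to 4500 nM.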

Compound 4, concentration for 50% growth inhibition: 2130 nM
The estimate for compound 4 lay 1.4-fold (0.15 log units) below the measured number; low and high end bracket the measured number.
By their numbers in this assay, from the lowest: compound 2; then compounds 4 and 3 (each within the scatter of the next); then compound 1.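

In this assay, putting (3,4-dichlorophenyl)amino in place of 3-(trifluoromethyl)phenyl on this carbonyl carbon gives a 1.9-fold lower number from compound 3 to compound 4 (0.27 log units; within the scatter). Within the data shown here, this is the first single-place step that can be read, and it shows that this position accepts the exchange with no change in growth inhibition that stands clear of the scatter, even though the carbonyl becomes a carbamoyl, a hydrogen-bond donor enters, and the ring substituents are replaced. No measurement of any other property of these compounds is available to account for this result.

Because the linking unit and the ring substituents change together, the step cannot show what each contributes alone, and effects of the two parts could be small or could offset each other. Keeping the carbonyl while carrying the 3,4-dichlorophenyl ring, or placing a methylene or an ether oxygen where the amino nitrogen stands, would pull the two parts apart, and a carboxylic acid or a morpholine on the ring would test how much else this position accepts.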